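Halogen swap on the benzyl group, cyclopropylamino series

A few compounds are considered here, and "the series" means these few. Any claim that something is new, unique, unknown or untested is made for them only; others in the source may bear on it.

Compound 1 `CCCCCCNc1nc(-c2ccccc2)nc2c1nnn2Cc1ccccc1Cl` gives 31 nM in an assay on Cerebral cortex for displacement of a labelled ligand from adenosine receptor A1 (Bos taurus); on this read-out lower numbers stand for stronger inhibition and higher numbers for weaker inhibition. Compound 2 `CCCCCCNc1nc(-c2ccccc2)nc2c1nnn2Cc1ccccc1F` gives 25 nM in this assay. Compound 3 `Clc1ccccc1Cn1nnc2c(NC3CC3)nc(-c3ccccc3)nc21` gives 11 nM in this assay, the lowest of the three numbers, with both other compounds beyond the scatter from it. The step of a 1.2-fold lower number from compound 1 to compound 2 (0.09 log units; within the scatter) corresponds to the change (fluoro in place of chloro on an aromatic carbon). The step of a 2.8-fold lower number from compound 1 to compound 3 (0.45 log units; beyond the scatter) corresponds to the change (cyclopropyl in place of hexyl on a nitrogen on an aromatic ring), which is also how the core of compound 3 differs from the core of compound 1. Compound 4 `Fc1ccccc1Cn1nnc2c(NC3CC3)nc(-c3ccccc3)nc21` is not yet measured in this assay. It differs from compound 3 by fluoro in place of chloro on an aromatic carbon, the same change as that from compound 1 to compound 2; the change occurs twice among the compounds shown, and the surroundings of the place agree word for word in both cases. The step of a 1.2-fold lower number from compound 1 to compound 2 (0.09 log units; within the scatter) lies within the scatter. On that basis a step of a 1.1-fold lower number from compound 3 to compound 4 (0.04 log units; within the scatter) is expected in this assay. Compound 4 is estimated at 10 nM in this assay, with a range from 5 nM to 20 nM.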

Compound 4, inhibition constant: 15 nM
Compound 4: the middle estimate sits 1.5-fold (0.18 log units) below what was measured; low and high end bracket the measured number.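

In this assay, fluoro in place of chloro on an aromatic carbon gives a 1.4-fold higher number from compound 3 to compound 4 (0.13 log units; within the scatter), and the two readings of this change on the two cores do not differ: the same change on two cores in this assay, a 1.2-fold lower number (0.09 log units; within the scatter) from compound 1 to compound 2 and a 1.4-fold higher number (0.13 log units; within the scatter) from compound 3 to compound 4, 1.7-fold (0.23 log units) apart, within the scatter of two such steps. Cyclopropyl in place of hexyl on the nitrogen gives a 1.7-fold lower number from compound 2 to compound 4 (0.22 log units; within the scatter) with fluoro on the benzyl group, and these two readings do not differ either, although only the step with chloro is printed as beyond the scatter: the same change on two cores in this assay, a 2.8-fold lower number (0.45 log units; beyond the scatter) from compound 1 to compound 3 and a 1.7-fold lower number (0.22 log units; within the scatter) from compound 2 to compound 4, 1.7-fold (0.23 log units) apart, within the scatter of two such steps. Both changes therefore carry from one core to the other within the scatter, but the evidence is a single set of four compounds, and since both halogen steps lie within the scatter, they show no measurable halogen effect that could be said to transfer.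

From the compounds shown here alone, it remains open whether a bromo or methyl group in the place of the halogen would read the same way. Going by these compounds, it is also open whether a propyl or butyl chain on the nitrogen would fit the same picture.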